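From 4-Fluorophenoxy to Pentan-3-yl on the Shared Core

This account rests on a few compounds, and the source may have more. Where it says the series, first, only, none or still open, it means among the compounds named here.

Compound 1 `COc1ccc(F)cc1CNCCCNc1ccnc2cc(-c3ccccc3)ccc12` gives 9.47 in a physicochemical assay for acid dissociation. Compound 2 `COc1ccc(F)cc1CNCCCNc1ccnc2cc(-c3cccc4ccccc34)ccc12` gives 9.47, and compound 3 `COc1ccc(F)cc1CNCCCNc1ccnc2cc(Oc3ccc(F)cc3)ccc12` gives 9.28. Compound 3 has the lowest of the three numbers, yet the steps of a number 0.19 log units lower from compound 1 to compound 3 (within the scatter) and a number 0.19 log units lower from compound 2 to compound 3 (within the scatter) are both within the scatter, as is no change at the digits printed from compound 1 to compound 2 (within the scatter). Compound 4 `CCC(CC)c1ccc2c(NCCCNCc3cc(F)ccc3OC)ccnc2c1` is not yet measured; it differs from compound 3 by pentan-3-yl in place of 4-fluorophenoxy on an aromatic carbon. All three measured steps change the group on this same aromatic carbon, and none moves the number beyond the scatter. The expected step of a number 0.17 log units higher from compound 3 to compound 4 (within the scatter) is therefore none beyond the scatter. Compound 4 is estimated at 9.45, with a range from 9.15 to 9.75.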

Compound 4, acid dissociation constant: 9.47
Compound 4: middle estimate off by 0.02 log units, on the low side; the range from low to high includes it.
By their numbers in this assay, from the lowest: compounds 3, 1, 2 and 4 (each within the scatter of the next).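

Until now, every group on this aromatic carbon carried an aromatic ring, whereas pentan-3-yl has no ring. In this assay, this change still gives a number 0.19 log units higher from compound 3 to compound 4 (within the scatter) and no change at the digits printed from compound 2 to compound 4 (within the scatter) as well as no change at the digits printed from compound 1 to compound 4 (within the scatter) and so, across these four compounds, a group with no ring and groups with rings all fall within the scatter. Nothing measured here offers an explanation for this result. From the compounds shown here alone, whether an amine or a carboxylic acid on this same carbon would move the number beyond the scatter remains open.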